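The compounds below may be only part of what the source reports. "The series", "measured", "known", "first", "only" and "open" are said of these compounds alone.

Compound 1 `O=C1c2sc(C#Cc3ccccc3)nc2CN1C1CC1` gives > 10000 nM in an assay on HEK293 cells for positive allosteric modulation of metabotropic glutamate receptor 5 (Homo sapiens), read by FLIPR, with a stated time of 1 h; on this read-out higher numbers stand for an effect only at larger amounts of compound and lower numbers for an effect already at smaller amounts.
Compound 2 `CN1CCc2nc(C#Cc3cccc(F)c3)sc2C1` gives > 10000 nM.
Compound 3 `CCN1CCc2nc(C#Cc3ccccc3)sc2C1` gives > 10000 nM.

Each of these three readings is a limit of the assay rather than a measured number: every compound shown sits at the limit of > 10000 nM in this assay, at which 3 of the 3 values shown sit, meaning none of them produced a half-maximal effect within the tested range. Compound 3 therefore stands where the other two stand, and no ordering among the three can be drawn from these readings.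

Compound 4 `CC1CC(C(=O)N2CCc3nc(C#Cc4ccccc4)sc3C2)C1` has not yet been measured. It differs from compound 3 in one place: (3-methylcyclobutyl)carbonyl in place of ethyl on an amine nitrogen in a ring. Among the measured compounds shown here, no measured pair in this set shows what such an exchange does, so the expectation rests on the change alone and carries real uncertainty. The expected step is an at least 10-fold lower number from compound 3 to compound 4 (1.00 log units; beyond the scatter), downward on this read-out, although a reading that again stops at the limit remains quite possible. Compound 4 is estimated at 1000 nM in this assay, with a plausible range from 100 nM to 10000 nM.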

Compound 4, half-maximal effective concentration: 81 nM
Compound 4: middle estimate off by 12-fold (1.09 log units), on the high side; the whole stated range lies above it.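

The amine nitrogen in the ring can carry a much larger group than ethyl, and the change at this one place separates a compound with no reading within the tested range from one with a measured value. In this assay, putting (3-methylcyclobutyl)carbonyl in place of ethyl gives an at least 120-fold lower number from compound 3 to compound 4 (2.09 log units; beyond the scatter). That step is a minimum and not an exact size, because the reading for compound 3 is only a limit: the limit of > 10000 nM in this assay, at which 3 of the 4 values shown sit.

The change brings in a carbonyl and a four-membered ring together, so the compounds shown cannot tell which of the two matters, or whether both are needed. An acetyl group, which keeps the carbonyl without the ring, and a cyclobutyl group bound directly to the nitrogen, which keeps the ring without the carbonyl, would separate the two.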